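This account rests on a few compounds, and the source may have more. Where it says the series, first, only, none or still open, it means among the compounds named here.

Working notes on a small set of compounds tested in a functional assay on MCF7 cells (Homo sapiens) for cytotoxicity, read by MTT assay, with a stated time of 6 days; on this read-out higher numbers stand for an effect only at larger amounts of compound and lower numbers for an effect already at smaller amounts. Compound 1 `COC(=O)c1c(-c2ccc([N+](=O)[O-])cc2)oc2ccccc2c1=O` is reported in this assay only as a limit, > 25 ug/mL. Compound 2 `COC(=O)c1c(-c2ccc(N)cc2)oc2ccccc2c1=O` likewise gives only a limit in this assay, > 25 ug/mL. The change between these two is amino in place of nitro on an aromatic carbon; the step that the two limits leave unreadable from compound 1 to compound 2 cannot be read from the two limits. Compound 3 `O=c1cc(-c2ccc([N+](=O)[O-])cc2)oc2ccc(O)cc12` carries a different core; how the core of compound 1 and the core of compound 3 differ is not broken down here. In this assay compound 3 is again reported only as a limit, > 25 ug/mL. All three values rest at the limit of > 25 ug/mL in this assay, at which 3 of the 3 values shown sit. Compound 4 `Nc1ccc(-c2cc(=O)c3cc(O)ccc3o2)cc1`, not yet measured in this assay, arises from compound 3 by amino in place of nitro on an aromatic carbon, the same change as that from compound 1 to compound 2, at the same kind of place. The step that the limit leaves unreadable from compound 3 to compound 4 is expected to be small, resting on the unreadable step that the two limits leave unreadable from compound 1 to compound 2 and on (the limit of > 25 ug/mL in this assay, at which 3 of the 3 values shown sit). The expected value for compound 4 is 30 ug/mL, most likely again a limit rather than a number.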

Compound 4, concentration for half-maximal effect: > 25 ug/mL
Compound 4 gave a limit, no number (the forecaster's own chance of this, stated with the estimate: 75%); the middle value is on the limit's open side.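

In this assay compound 4 gives only a limit, > 25 ug/mL. Since compound 3 is also reported only as a limit, no step can be read from compound 3 to compound 4, so amino in place of nitro remains unsized. The compounds shown leave open what actual number any of them would give in this assay, and every value rests at one limit: the limit of > 25 ug/mL in this assay, at which 4 of the 4 values shown sit.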